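Ester variation on a bicyclic enone core: a chloro substituent

The source may report more compounds than this note shows. Statements on the series, on what has been measured and on what is new or still open speak of the compounds shown alone.

Measured so far:
- compound 1 `CCCC(=O)O[C@]12C=CC(=O)C[C@H]1OCC2`: 2.7 ug/mL
- compound 2 `CCCCCC(=O)O[C@]12C=CC(=O)C[C@H]1OCC2`: 1.8 ug/mL
- compound 3 `O=C1C=C[C@]2(OC(=O)c3ccccc3)CCO[C@@H]2C1`: 1.6 ug/mL

All three compounds share the same core and differ only in the acid part of the ester. In a functional assay on HeLa S3 cells (Homo sapiens) for cytotoxicity (a higher number here means a weaker inhibitor, a lower number a stronger inhibitor), compound 3 gives the lowest of the three numbers, but every measured step lies within the scatter: a 1.5-fold lower number from compound 1 to compound 2 (0.18 log units; within the scatter), a 1.7-fold lower number from compound 1 to compound 3 (0.23 log units; within the scatter) and a 1.1-fold lower number from compound 2 to compound 3 (0.05 log units; within the scatter). Taken together, the three compounds behave as one group, with no step that a repeat measurement could not wipe out.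

Compound 4 `O=C1C=C[C@]2(OC(=O)c3ccc(Cl)cc3)CCO[C@@H]2C1` keeps the benzoate of compound 3 and adds one change: chloro in place of hydrogen on an aromatic carbon. Among the compounds with values here, no measured step touches the aromatic ring itself; the steps seen so far swap one acyl chain for another or for phenyl, and all of them are small. The data therefore give no reason to expect a step beyond the scatter in this assay from compound 3 to compound 4 in either direction.

The expectation for compound 4 is a number close to that of compound 3, with the step of no change at the digits printed from compound 3 to compound 4 (within the scatter) estimated as negligible. Compound 4 is thus estimated at 1.6 ug/mL, within a range of 0.6 ug/mL to 4 ug/mL.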

Compound 4, half-maximal inhibitory concentration: 0.9 ug/mL
Estimate against measurement, compound 4: 1.8-fold (0.25 log units) above, within the range that was stated.
By their numbers in this assay, from the lowest: compounds 4, 3, 2 and 1 (each within the scatter of the next, the first and the last beyond it).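

The earlier steps shown here only exchanged one acyl group for another, whereas this one alters the aromatic ring of the benzoate itself. In this assay chloro in place of hydrogen gives a 1.8-fold lower number from compound 3 to compound 4 (0.25 log units; within the scatter) and so stays within the scatter, which shows that this ring carbon, para to a large group, can carry a chlorine atom without a step that a repeat measurement could not wipe out. Within the data shown here, compound 4 therefore fits with the other esters in this comparison, and the single step does not establish that chloro at this position has a real effect on the number, while nothing measured here bears on the size of the step.

As far as these compounds go, it remains open whether a different group on this same aromatic carbon, such as an amine, a carboxylic acid or a methoxy group, would stay within the scatter of compound 3 or move clearly beyond it. Also open, from the compounds shown here alone, is whether chloro on another carbon of the ring, or a longer chain in place of the pentyl group of compound 2, would produce a step large enough to read.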